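The source may report more compounds than this note shows. Statements on the series, on what has been measured and on what is new or still open speak of the compounds shown alone.

In a functional assay on RXF 393 cells (Homo sapiens) for inhibition, read by sulforhodamine B assay, with a stated time of 48 h, tested at 10 uM (a lower number here means less inhibition of growth, a higher number more inhibition of growth at the concentration tested), compound 1 (`COc1ccc(-c2nc3sc(-c4ccccc4)cn3n2)cc1`) gives 24% and compound 2 (`COc1cc(-c2nc3sc(-c4ccccc4)cn3n2)cc(OC)c1OC`) gives 17% in the same test. Going by the values given here, these two values lie within the scatter, so compound 1 stands level with the only other measured compound. Compound 3 (`c1ccc(-c2nc3sc(-c4ccccc4)cn3n2)cc1`) differs from compound 1 by a single change (hydrogen in place of methoxy on an aromatic carbon): hydrogen in place of methoxy on an aromatic carbon, para to a large group. Among the compounds with values here, no measured step covers this change, so no shift beyond the scatter is expected in this assay. The estimated step of a number 4 percentage points lower from compound 1 to compound 3 (within the scatter) stays inside that scatter. Compound 3 is expected at 20% with an estimated range of 5% to 35% for now.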

Compound 3, percent growth inhibition at one concentration: 9%
Beside the measured number, compound 3's estimate is 11 percentage points above it, within the range that was stated.
By their numbers in this assay, from the lowest: compounds 3, 2 and 1 (each within the scatter of the next, the first and the last beyond it).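

In this assay, going by these compounds alone, hydrogen in place of methoxy on an aromatic carbon, para to a large group, gives the first measured single-place step: a number 15 percentage points lower from compound 1 to compound 3 (beyond the scatter). This place therefore responds to substitution, and the methoxy-bearing compound reads higher in growth inhibition at the tested concentration. No available evidence accounts for the size of this step.

As far as these compounds go, whether an ethoxy, a hydroxyl, an amine or a fluorine at this place would match methoxy stays open. So does whether the same change would produce a similar step elsewhere on the shared core.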